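Swapping the Ethoxyphenyl Amine for a Halogenated Ring

The compounds below may be only part of what the source reports. "The series", "measured", "known", "first", "only" and "open" are said of these compounds alone.

Three analogues of one shared core have been examined in a functional assay on MCF7 cells (Homo sapiens) for cytotoxicity, read by MTT assay, with a stated time of 72 h; on this read-out higher numbers stand for weaker inhibition and lower numbers for stronger inhibition. Compound 1 `FC(F)(F)c1ccc(CSc2nc(Nc3cccc(C(F)(F)F)c3)c3ccccc3n2)cc1` gives 15300 nM in this assay. Compound 2 `FC(F)(F)c1ccc(CSc2nc(Nc3cccc(Br)c3)c3ccccc3n2)cc1` gives 25600 nM in this assay, and between them lies a 1.7-fold higher number from compound 1 to compound 2 (0.22 log units; within the scatter). Compound 3 `CCOc1ccc(Nc2nc(SCc3ccc(C(F)(F)F)cc3)nc3ccccc23)cc1` instead carries a 4-ethoxyphenyl on the amine nitrogen. In this assay compound 3 reaches only the limit of the measurement, > 50000 nM, so no number is known for it. Compound 3 thus stands at the limit of > 50000 nM in this assay, at which 1 of the 3 values shown sits, the weakest position the numbers can show.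

The two steps that lead into compound 3 both run the same way: an at least 3.2-fold higher number from compound 1 to compound 3 (0.51 log units; beyond the scatter), and an at least 1.9-fold higher number from compound 2 to compound 3 (0.29 log units; that floor lies within the scatter). Compound 4 `Fc1ccc(Nc2nc(SCc3ccc(C(F)(F)F)cc3)nc3ccccc23)cc1Cl` reverses the type of change, with 3-chloro-4-fluorophenyl in place of 4-ethoxyphenyl on a nitrogen on an aromatic ring. The entering ring, bearing chlorine and fluorine, resembles the halogen- and trifluoromethyl-bearing rings of compounds 1 and 2 more than it does the ethoxy-bearing ring of compound 3, so a return toward their numbers is anticipated, though the exact substitution pattern of compound 4 is matched by neither.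

Compound 4 is therefore expected to give about 25000 nM in this assay, most likely between 10000 nM and 60000 nM. The step this estimate implies is an at least 2.0-fold lower number from compound 3 to compound 4 (0.30 log units; that floor lies within the scatter).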

Compound 4, half-maximal inhibitory concentration: 23000 nM
The estimate for compound 4 lay 1.1-fold (0.04 log units) above the measured number; measured number inside the range.
By their numbers in this assay, from the lowest: compounds 1, 4 and 2 (each within the scatter of the next). At a limit, above all of these: compound 3.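

Replacing the 4-ethoxyphenyl on this nitrogen with 3-chloro-4-fluorophenyl gives, in this assay, an at least 2.1-fold lower number from compound 3 to compound 4 (0.33 log units; beyond the scatter), so compound 3 now lies clearly apart from a second analogue, where the floor of its step from compound 2 could not show this. The new ring does not separate from the two earlier rings, with a 1.1-fold lower number from compound 2 to compound 4 (0.05 log units; within the scatter) and a 1.5-fold higher number from compound 1 to compound 4 (0.18 log units; within the scatter), so among compounds 1, 2 and 4 this position tolerates three different substitution patterns without a readable change in the number. Compound 3 alone still has a limit and no number, which makes its step a floor and not a size: the limit of > 50000 nM in this assay, at which 1 of the 4 values shown sits.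

As far as these compounds go, how far compound 3 truly lies from the other three therefore stays open, as does whether the ethoxy group itself or only its presence on this ring goes with the weaker result. The compounds shown also leave open what a methoxy group, an amine or a carboxylic acid on this ring would give, and whether a ring bearing only fluorine would stay with compounds 1, 2 and 4.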